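Anilinoquinoxaline sulfones: aryl amine swap on a bromo core

A few compounds are considered here, and "the series" means these few. Any claim that something is new, unique, unknown or untested is made for them only; others in the source may bear on it.

The shared core carries an aryl amine on a nitrogen on an aromatic ring. Compound 1 `COc1cc(Nc2nc3ccccc3nc2S(=O)(=O)c2ccc(C)cc2)cc(OC)c1` is inactive at the limit of a functional assay on HCT-116 cells (Homo sapiens) for cytotoxicity, read by MTT assay, with a stated time of 72 h (on this read-out higher numbers stand for weaker inhibition and lower numbers for stronger inhibition), giving only > 50000 nM. Compound 2 `Cc1ccc(S(=O)(=O)c2nc3ccccc3nc2Nc2ccc(N)cc2)cc1` differs by 4-aminophenyl in place of 3,5-dimethoxyphenyl on a nitrogen on an aromatic ring and in this assay gives 11500 nM, so the step is an at least 4.3-fold lower number from compound 1 to compound 2 (0.63 log units; beyond the scatter). Compound 3 `COc1cc(Nc2nc3ccccc3nc2S(=O)(=O)c2ccc(Br)cc2)cc(OC)c1` differs from compound 1 in the core by bromo in place of methyl on an aromatic carbon; in this assay compound 3 sits at the limit, > 50000 nM, so the step that the two limits leave unreadable from compound 1 to compound 3 cannot be read, since the limit of > 50000 nM in this assay, at which 2 of the 3 values shown sit, holds two of three values. Compound 4 `Nc1ccc(Nc2nc3ccccc3nc2S(=O)(=O)c2ccc(Br)cc2)cc1` carries the same change as compound 2, (4-aminophenyl in place of 3,5-dimethoxyphenyl on a nitrogen on an aromatic ring), on the bromo core. Its step from compound 3 is expected to be an at least 4.1-fold lower number from compound 3 to compound 4 (0.61 log units; beyond the scatter), resting on the measured step of an at least 4.3-fold lower number from compound 1 to compound 2 (0.63 log units; beyond the scatter). Compound 4 is thus expected to give about 12000 nM, between 4000 nM and 40000 nM.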

Compound 4, half-maximal inhibitory concentration: 1390 nM
Compound 4: middle estimate off by 8.6-fold (0.94 log units), on the high side, outside the stated range (below it).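

In this assay, 4-aminophenyl in place of 3,5-dimethoxyphenyl lowers the number on the bromo core as well, with an at least 35-fold lower number from compound 3 to compound 4 (1.55 log units; beyond the scatter), so the direction of the change carries over, but its size cannot be compared: the same change on two cores in this assay, an at least 4.3-fold lower number (0.63 log units; beyond the scatter) from compound 1 to compound 2 and an at least 35-fold lower number (1.55 log units; beyond the scatter) from compound 3 to compound 4; the limit leaves it open whether they differ

On the 4-aminophenyl compounds, bromo in place of methyl gives an 8.3-fold lower number from compound 2 to compound 4 (0.92 log units; beyond the scatter), and this single pair does not show that the bromo group helps on other cores.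

The matching step on the 3,5-dimethoxyphenyl compounds cannot be read: the limit of > 50000 nM in this assay, at which 2 of the 4 values shown sit.

Still open, as far as these compounds go, is whether the lower number depends on the amine itself, which a phenyl group carrying a hydroxyl or a carboxylic acid in its place could test. From the compounds shown here alone, it is also open whether chloro or methoxy in place of bromo would follow the same course.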